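A larger ring on the side chain of compound 1

The source may report more compounds than this note shows. Statements on the series, on what has been measured and on what is new or still open speak of the compounds shown alone.

In a physicochemical assay for solubility, in phosphate buffer, measured as kinetic solubility, at pH 7.4 (on this read-out higher numbers stand for higher solubility and lower numbers for lower solubility), compound 1 `Cc1ccccc1-c1nc(CN2CCC(C(=O)NCCCN3CCC(C)CC3)CC2)c(C)o1` gives > 67 ug/mL as a limit of the assay and not a number. Compound 2 `Cc1oc(-c2c(F)cccc2F)nc1CN1CCC(C(=O)NCCCN2C[C@H](C)C[C@H](C)C2)CC1` gives > 72 ug/mL as a limit too. Compound 3 `Cc1ccccc1-c1nc(CN2CCC(C(=O)NCCCN3CCCC(C(C)C)C3)CC2)c(C)o1` departs from compound 1 on a saturated chain carbon, three bonds along the chain from an amide-type nitrogen, by the change a group of 9 heavy atoms (8 carbon, 1 nitrogen; one six-membered non-aromatic ring with 1 hetero atom) in place of a group of 7 heavy atoms (6 carbon, 1 nitrogen; one six-membered non-aromatic ring with 1 hetero atom), on a saturated chain carbon, three bonds along the chain from an amide-type nitrogen where the 4-methylpiperidin-1-yl group leaves. For the measured compounds named here, no measured step is at hand, so only a small downward step is expected in this assay from this change. The expected step is an at least 1.2-fold lower number from compound 1 to compound 3 (0.08 log units; that floor lies within the scatter) and may stay within the usual scatter. For compound 3 the estimate is 55 ug/mL with an expected range of 20 ug/mL to 85 ug/mL in this measurement.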

Compound 3, solubility: > 71 ug/mL
Compound 3: no number, only a limit; the forecaster's own chance of this, stated with the estimate: 55%; at least 1.2-fold (0.11 log units) between middle value and limit.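

For the compounds shown here, compound 1 and compound 3 both stand only as limits in this assay, so no step between them can be read. From the compounds shown here alone, whether replacing the 4-methylpiperidin-1-yl group changes the read-out at all remains open.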